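Removing the isopropyl group from compound 2

The source may report more compounds than this note shows. Statements on the series, on what has been measured and on what is new or still open speak of the compounds shown alone.

Compound 1 `CC(C)c1ccc(-c2nc(SCc3cn(CC(=O)NC(=O)Nc4ccccn4)nn3)nc(Nc3cccc(C(F)(F)F)c3)c2C#N)cc1`: > 64000 nM
Compound 2 `Cc1ccc(Nc2nc(SCc3cn(CC(=O)NC(=O)Nc4ccccn4)nn3)nc(-c3ccc(C(C)C)cc3)c2C#N)cc1`: 3360 nM

Of the compounds shown here, two have been tested in a functional assay on MGC-803 cells (Homo sapiens) for inhibition, read by MTT assay, with a stated time of 72 h; a lower number here means a stronger inhibitor, a higher number a weaker inhibitor. Compound 1 did not reach a number; its result is a limit of the assay, > 64000 nM, as the limit of > 64000 nM in this assay, at which 1 of the 2 values shown sits, records. Among the measured compounds shown here, compound 2 gives 3360 nM in this assay, and it is the only compound with an actual number. The step of an at least 19-fold lower number from compound 1 to compound 2 (1.27 log units; beyond the scatter) shows a large change, but it concerns a different part of the shared core than the change considered here.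

Compound 3 `Cc1ccc(Nc2nc(SCc3cn(CC(=O)NC(=O)Nc4ccccn4)nn3)nc(-c3ccccc3)c2C#N)cc1` differs from compound 2 by hydrogen in place of isopropyl on an aromatic carbon. For the measured compounds named here, no measured step touches this group, so nothing among the tested compounds tells how large a change in this assay to expect, or in which direction. The step of a 1.8-fold higher number from compound 2 to compound 3 (0.25 log units; within the scatter) is therefore an estimate resting on no direct comparison. Compound 3 is expected to give about 6000 nM in this assay, with a likely range from 1500 nM to 30000 nM.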

Compound 3, half-maximal inhibitory concentration: 7870 nM
Compound 3: middle estimate off by 1.3-fold (0.12 log units), on the low side; the measured number falls inside the stated range.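

Among the compounds shown here, replacing isopropyl with hydrogen on the aromatic carbon gives a 2.3-fold higher number from compound 2 to compound 3 (0.37 log units; beyond the scatter) in this assay and is the first measured change at this position, so the 4-isopropylphenyl group does affect the result here. The change is modest, and the phenyl of compound 3 still gives an actual number instead of a limit, which shows that the isopropyl group is not needed for a measurable result in this pair. For the compounds shown here, the one piece of supporting information available concerns a limit reached elsewhere and does not bear on this change, so nothing here explains why the number rises.

With only isopropyl and hydrogen shown at this position, it remains open how a methyl, a tert-butyl, a methoxy group, an amine or a carboxylic acid would behave there, and whether any of them would give a lower number than isopropyl. Going by these compounds, it is also open whether the same change would have a similar effect alongside the 3-(trifluoromethyl)phenyl group of compound 1, whose result is a limit.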